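The source may hold more compounds than are shown below. What is called first, only, known or untested is meant among the compounds shown, and "the series" means these compounds.

Four compounds sharing one core are at issue here, and the record in a physicochemical assay for solubility, with a stated time of 3 days, at pH 7 (a higher number here means a more soluble compound, a lower number a less soluble compound), is thin. Compound 1 `CN1CCC(Oc2ccc(-c3nc4cc(C(N)=O)ccc4[nH]3)cc2)CC1` gives > 400000 nM, which is a limit of the assay and not a number. For compound 2 `NC(=O)c1ccc2[nH]c(-c3ccc(OCC4CCCNC4)cc3)nc2c1` the entry reads "not determined" (no result reported). Within the data shown here, compound 3 `Cc1ccc(CN2CCCCC2CCOc2ccc(-c3nc4cc(C(N)=O)ccc4[nH]3)cc2)cc1` gives 97000 nM, and this is the only actual number in the set, so its place relative to the others cannot be given as a measured gap.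

Compound 4 `NC(=O)c1ccc2[nH]c(-c3ccc(OCCC4CCCCN4C(=O)c4ccccc4)cc3)nc2c1` has not yet been measured in this assay. It differs from compound 3 in one place, with benzoyl in place of 4-methylbenzyl on an amine nitrogen in a ring. The two groups are the same size in heavy atoms, but the benzoyl brings a hydrogen-bond acceptor that the 4-methylbenzyl lacks.

Among the measured compounds shown here, no two measured compounds differ in just one place, so no measured step can serve as a guide, and the expectation starts from compound 3 at 97000 nM. A decrease somewhat beyond the usual scatter is expected, and the estimated step is a 3.2-fold lower number from compound 3 to compound 4 (0.51 log units; beyond the scatter). Compound 4 is estimated at 30000 nM, with an expected range from 5000 nM to 130000 nM.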

Compound 4, solubility: 18000 nM
Beside the measured number, compound 4's estimate is 1.7-fold (0.22 log units) above it; measured number inside the range.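

In this assay, the change on the ring nitrogen gives the set its first step that can be read: a 5.4-fold lower number from compound 3 to compound 4 (0.73 log units; beyond the scatter). This shows that the number is sensitive to the group at this position, on an amine nitrogen in a ring and next to the ring atom that bears a large group, even though 4-methylbenzyl and benzoyl have the same count of heavy atoms and each carries one six-membered aromatic ring of carbon only. No measurement shown here bears on what lies behind the step, which therefore stands as an observation on this one pair.

An acetyl, a methanesulfonyl or the free ring amine on this nitrogen would show whether the step goes with the carbonyl or belongs to benzoyl alone, while a 4-methylbenzoyl would separate the effect of the carbonyl from that of the methyl on the aromatic ring. Compounds 1 and 2 differ from compound 4 in more than one place, so they give no reading of this position.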